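Hydroxyamino in place of azetidine on a sulfonyl sulfur

A few compounds are considered here, and "the series" means these few. Any claim that something is new, unique, unknown or untested is made for them only; others in the source may bear on it.

Compound 1 `[O-][S+]1CC(Nc2nonc2/C(=N/O)Nc2ccc(F)c(Br)c2)C1` gives 79 nM in an assay on HeLa cells for inhibition of Indoleamine 2,3-dioxygenase 1 (Homo sapiens), read by spectrophotometry, with a stated time of 24 h; on this read-out higher numbers stand for an effect only at larger amounts of compound and lower numbers for an effect already at smaller amounts.
Compound 2 `O=S1(=O)CC(Nc2nonc2/C(=N/O)Nc2ccc(F)c(Br)c2)C1` gives 59 nM in this assay.
Compound 3 `O=S(=O)(CCNc1nonc1/C(=N/O)Nc1ccc(F)c(Br)c1)N1CCC1` gives 143 nM in this assay.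

Compound 3 has the highest number of the three: a 1.8-fold higher number from compound 1 to compound 3 (0.26 log units; within the scatter), and a 2.4-fold higher number from compound 2 to compound 3 (0.38 log units; beyond the scatter). Compound 4 `O=S(=O)(CCNc1nonc1/C(=N/O)Nc1ccc(F)c(Br)c1)NO` differs from compound 3 by hydroxyamino in place of azetidin-1-yl on a sulfonyl sulfur. Among the measured compounds shown here, no measured step alters the group on the sulfonyl sulfur; the measured steps each exchanged the whole group on the nitrogen of the shared core, and they were small: a 1.3-fold lower number from compound 1 to compound 2 (0.13 log units; within the scatter), a 1.8-fold higher number from compound 1 to compound 3 (0.26 log units; within the scatter), a 2.4-fold higher number from compound 2 to compound 3 (0.38 log units; beyond the scatter). Since every such exchange moved the number little, the expectation for compound 4 is no step beyond the scatter: a 1.3-fold lower number from compound 3 to compound 4 (0.11 log units; within the scatter). Compound 4 is therefore estimated at 110 nM, with a range from 40 nM to 300 nM.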

Compound 4, half-maximal effective concentration: > 800 nM
Compound 4: no number, only a limit; the forecaster's own chance of this, stated with the estimate: 3%; at least 7.2-fold (0.86 log units) between middle value and limit.
By their numbers in this assay, from the lowest: compounds 2, 1 and 3 (each within the scatter of the next, the first and the last beyond it). At a limit, above all of these: compound 4.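

Compound 4 gives no number, only a limit: the limit of > 800 nM in this assay, at which 1 of the 4 values shown sits.
Hydroxyamino in place of azetidin-1-yl on the sulfonyl sulfur gives an at least 5.5-fold higher number from compound 3 to compound 4 (0.74 log units; beyond the scatter) and so shows that this one place can matter more than the exchanges among compounds 1, 2 and 3 suggested. Compound 4 also stands well apart from the two cyclic compounds, with an at least 13-fold higher number from compound 2 to compound 4 (1.13 log units; beyond the scatter) and an at least 10-fold higher number from compound 1 to compound 4 (1.00 log units; beyond the scatter) on the same read-out.

From the compounds shown here alone, whether the rise follows from the hydroxy on that nitrogen or from losing the azetidine ring stays open. A plain amino group, a methylamino group or a pyrrolidine on the sulfonyl sulfur would help separate the two.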